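Swapping Methoxy for Bromo: What Compound 3 Might Show

This account rests on a few compounds, and the source may have more. Where it says the series, first, only, none or still open, it means among the compounds named here.

Compound 1, `CC(=O)c1cc2ccc(OCCCCCn3cc(CNC(=O)CCCCC4CCSS4)nn3)cc2oc1=O`, gives 18.2% in a functional assay on PC-12 cells (Rattus norvegicus) for cytotoxicity, read by MTT assay, with stated times of 3 h and 2 h, tested at 50 uM; on this read-out higher numbers stand for a stronger effect at the one concentration tested and lower numbers for a weaker effect.
Compound 2, `COc1ccc(-c2cc3ccc(OCCCCCn4cc(CNC(=O)CCCCC5CCSS5)nn4)cc3oc2=O)cc1`, gives 52.8% in this assay.

Compound 2 stands highest of the two measured values. Among the compounds with values here, the only measured step, a number 34.6 percentage points higher from compound 1 to compound 2 (beyond the scatter), concerns a different position and does not bear on the change now considered.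

Compound 3, `O=C(CCCCC1CCSS1)NCc1cn(CCCCCOc2ccc3cc(-c4ccc(Br)cc4)c(=O)oc3c2)nn1`, differs from compound 2 by bromo in place of methoxy on an aromatic carbon. Within the data shown here, with no measured step touching this position, the author expects no shift beyond the scatter in this assay. Compound 3 is therefore estimated at 50%, within 30% to 70%. That estimate means a number 2.8 percentage points lower from compound 2 to compound 3 (within the scatter).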

Compound 3, a percentage reported as activity, at one concentration (the size of the read-out at that concentration, not a potency): 53.6%
Compound 3: the middle estimate sits 3.6 percentage points below what was measured; the measured number falls inside the stated range.
By their numbers in this assay, from the lowest: compound 1; then compounds 2 and 3 (each within the scatter of the next).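

Placing bromo where methoxy stood on this ring leaves the number in this assay within the scatter, with a number 0.8 percentage points higher from compound 2 to compound 3 (within the scatter) in this single exchange, so the two groups cannot be told apart at this position. The earlier difference from acetyl also holds for the 4-bromophenyl group, with a number 35.4 percentage points higher from compound 1 to compound 3 (beyond the scatter) for that change. No available evidence gives a reason for either step.

The compounds shown leave open whether an amine or a carboxylic acid at this same place would keep the number at this level. They also do not show what a bare phenyl group would give.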